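The compounds below may be only part of what the source reports. "The series", "measured", "known", "first", "only" and "open" are said of these compounds alone.

Among the compounds with values here, compound 1 `Cc1cccc(Cl)c1NC(=O)CN1CCN(c2nnc(Cc3ccncc3)c3ccccc23)CC1` holds the lower of the two numbers known so far: in a functional assay on MDA-MB-231 cells (Homo sapiens) for cytotoxicity, read by MTT assay, with a stated time of 72 h (on this read-out lower numbers stand for stronger inhibition and higher numbers for weaker inhibition), compound 1 gives 2670 nM. Compound 2 `Cc1ccc(F)cc1NC(=O)CN1CCN(c2nnc(Cc3ccccc3)c3ccccc23)CC1` differs from it in more than one place, and in this assay compound 2 gives 19200 nM. Compound 3 `O=C(CN1CCN(c2nnc(Cc3ccncc3)c3ccccc23)CC1)Nc1cc(C(F)(F)F)ccc1Cl` has not been measured; it carries 2-chloro-5-(trifluoromethyl)phenyl in place of 2-chloro-6-methylphenyl on an amide-type nitrogen. Within the data shown here, no measured pair differs only at that spot, so the size of the step is open. A small change, near or just beyond the scatter, is expected, with the estimated step being a 1.3-fold higher number from compound 1 to compound 3 (0.12 log units; within the scatter). Compound 3 is expected near 3500 nM, within 1000 nM to 12000 nM.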

Compound 3, half-maximal inhibitory concentration: 3.7 nM
Estimate against measurement, compound 3: 950-fold (2.98 log units) above; the measured number lies below the stated range.
By their numbers in this assay, from the lowest: compound 3; then compound 1; then compound 2.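

This position on the amide-type nitrogen proves highly sensitive in this assay: 2-chloro-5-(trifluoromethyl)phenyl in place of 2-chloro-6-methylphenyl gives a 720-fold lower number from compound 1 to compound 3 (2.86 log units; beyond the scatter). The rest of the molecule stays the same, so this whole step belongs to that single swap of groups. Nothing measured here indicates why the step is so large.

The compounds shown leave open whether the trifluoromethyl group itself carries the step or whether the methyl leaving its old place matters more. A 2-chloro-5-methylphenyl group or a nitrile in place of trifluoromethyl would separate these two readings.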